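This account rests on a few compounds, and the source may have more. Where it says the series, first, only, none or still open, it means among the compounds named here.

Measured so far in a functional assay on HepG2 cells (Homo sapiens) for antiproliferative activity, read by MTT assay, with a stated time of 24 h; on this read-out higher numbers stand for weaker inhibition and lower numbers for stronger inhibition:
- Compound 1 `COc1cc(OC)c(-c2coc3cc(OCc4ccc(Br)cc4)ccc3c2=O)cc1OC`: 1050 nM
- Compound 2 `COc1cc(OC)c(-c2coc3cc(OCc4cccc(F)c4)ccc3c2=O)cc1OC`: 1230 nM

Compound 2 stands level with compound 1 within the scatter. Compound 3 `COc1cc(OC)c(-c2coc3cc(OCc4cccc(Cl)c4)ccc3c2=O)cc1OC` differs from compound 2 by chloro in place of fluoro on an aromatic carbon. Within the data shown here, only one measured step bears on this, and it is a larger swap, 3-fluorophenyl in place of 4-bromophenyl: a 1.2-fold higher number from compound 1 to compound 2 (0.07 log units; within the scatter). With that step so small, no change beyond the scatter is expected in this assay. The expected change is a 1.1-fold lower number from compound 2 to compound 3 (0.03 log units; within the scatter). The estimate for compound 3 is 1150 nM, with an expected range of 600 nM to 2200 nM.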

Compound 3, half-maximal inhibitory concentration: 750 nM
The estimate for compound 3 lay 1.5-fold (0.19 log units) above the measured number; the range from low to high includes it.
By their numbers in this assay, from the lowest: compounds 3, 1 and 2 (each within the scatter of the next).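

In this assay, chloro in place of fluoro on an aromatic carbon gives a 1.6-fold lower number from compound 2 to compound 3 (0.21 log units; within the scatter) and stays within the scatter, so this halogen swap leaves the number level at this position. Moving to the 3-chlorophenyl from the 4-bromophenyl gives a 1.4-fold lower number from compound 1 to compound 3 (0.15 log units; within the scatter) and also stays within the scatter, so all three halogen-bearing benzyl ethers stand level. No evidence bears on this result.

Going by these compounds, whether an amine or a carboxylic acid on this aromatic ring would shift the number beyond the scatter remains open. On these data alone, the effect of a longer chain in place of the benzyl link also remains open.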